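A few compounds are considered here, and "the series" means these few. Any claim that something is new, unique, unknown or untested is made for them only; others in the source may bear on it.

Measured compounds:
- compound 1, `CC(=O)N[C@@H](CCCN=C(N)N)C(=O)N[C@@H](C)C(=O)NO` — in an assay on isolated protein for inhibition of bone morphogenetic protein 1 (Homo sapiens) (on this read-out lower numbers stand for stronger inhibition and higher numbers for weaker inhibition), compound 1 gives > 800000 nM, which is a limit of the assay rather than a number.
- compound 2, `CC[C@H](C)[C@H](NS(=O)(=O)c1cc(Br)c(Br)s1)C(=O)N[C@@H](CNC(=O)OCc1ccccc1)C(=O)NO` — in this assay compound 2 gives 52 nM.
- compound 3, `CNC(=O)[C@H](CCC(N)=O)NC(=O)[C@H](CC(=O)O)CC(=O)NO` — in this assay compound 3 gives 68000 nM.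

Among the two numbers shown, compound 2 has the lowest one; the nearest is that of compound 3, and the gap between them lies beyond the usual scatter. Compound 1 contributes only a limit, (the limit of > 800000 nM in this assay, at which 1 of the 3 values shown sits).

Compound 4, `CC[C@H](C)[C@H](NS(=O)(=O)c1ccc(Br)c(Br)c1)C(=O)N[C@@H](CNC(=O)OCc1ccccc1)C(=O)NO`, has not yet been measured. It differs from compound 2 in one place: 3,4-dibromophenyl in place of 4,5-dibromothiophen-2-yl on a sulfonyl sulfur. The ring carrying the two bromine atoms is exchanged, while the sulfonyl group and the rest of the molecule stay as they are. Among the measured compounds shown here, no measured pair shows a change of this kind, so the expectation rests on the size of the change alone.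

The change touches one ring only. A small step is expected from compound 2 to compound 4, a 1.3-fold higher number from compound 2 to compound 4 (0.13 log units; within the scatter), of a size that may fall within the scatter. For compound 4 a value of about 70 nM is estimated, expected between 25 nM and 200 nM.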

Compound 4, half-maximal inhibitory concentration: 26 nM
Compound 4: middle estimate off by 2.7-fold (0.43 log units), on the high side, and the stated range covers the measured number.
By their numbers in this assay, from the lowest: compounds 4 and 2 (each within the scatter of the next); then compound 3. At a limit, above all of these: compound 1.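

In this assay, exchanging the 4,5-dibromothiophen-2-yl group on the sulfonyl sulfur for 3,4-dibromophenyl gives a 2.0-fold lower number from compound 2 to compound 4 (0.30 log units; within the scatter), so the two compounds cannot be told apart on this read-out. Among the compounds shown here, the earlier compounds offered no pair differing in one place, and this step is the first sign that the ring at this position can change, from a five-membered aromatic ring with a sulfur atom to a six-membered one of carbon only, with the value staying within the scatter. Nothing shown here bears on what lies behind this result.

Whether the two bromine atoms matter stays open, since neither a plain phenyl ring nor a ring carrying an amine or a carboxylic acid in their place appears among these compounds. A single step at this position also supports no general trend.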